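The source may report more compounds than this note shows. Statements on the series, on what has been measured and on what is new or still open speak of the compounds shown alone.

Compound 1 `COc1cc(-n2c(-c3ccccc3)cn(C(C)=O)c2=O)cc(OC)c1OC` opens this small set. In a functional assay on PC-3 cells (Homo sapiens) for cytotoxicity, read by MTT assay, with a stated time of 48 h (on this read-out lower numbers stand for stronger inhibition and higher numbers for weaker inhibition), compound 1 gives > 50000 nM, which is a limit of the assay rather than a measured number. Compound 2 `COc1cc(-n2c(-c3ccc(Cl)cc3)cn(C(C)=O)c2=O)cc(OC)c1OC` carries the entry "not determined" (no result reported) in this assay, so no number yet places it among the others. Compound 3 `COc1ccc(-c2cn(C(C)=O)c(=O)n2-c2cc(OC)c(OC)c(OC)c2)cc1` differs from compound 2 by one change only: methoxy in place of chloro on an aromatic carbon. For the measured compounds named here, with no measured step to lean on, a shift no larger than the usual scatter, in either direction, is expected from this change. Compound 3 is therefore estimated at 30000 nM, with a range from 5000 nM to 150000 nM.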

Compound 3, half-maximal inhibitory concentration: 19700 nM
Compound 3: middle estimate off by 1.5-fold (0.18 log units), on the high side, within the range that was stated.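

In this assay, for the compounds shown here, compound 3 gives the first measured number in this set, which shows that this position tolerates a change that can be read. Methoxy in place of hydrogen at this position gives an at least 2.5-fold lower number from compound 1 to compound 3 (0.40 log units; beyond the scatter). Compound 1 stands at a limit rather than a number, so the full size of this step stays unknown: the limit of > 50000 nM in this assay, at which 1 of the 3 values shown sits.

The step between the 4-chlorophenyl of compound 2 and the 4-methoxyphenyl of compound 3 cannot be read. As far as these compounds go, what a hydroxyl, an amine or a longer ethoxy chain would do at this position remains open.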